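A Carboxy Group in Place of Tert-Butoxycarbonyl

The compounds below may be only part of what the source reports. "The series", "measured", "known", "first", "only" and "open" are said of these compounds alone.

Measured in an ADME assay on the whole organism (plasma, Rattus norvegicus, strain Sprague-Dawley) for pharmacokinetics, read by LC-MS, with a stated time of 4 h, at a dose of 15 mg/kg by the intraduodenal route; a higher number here means more compound in the circulation at the dose given, a lower number less compound in the circulation:
Compound 1 `C=C[C@@H]1C[C@]1(NC(=O)[C@@H]1C[C@@H](Oc2nccc3cc(OC)ccc23)CN1C(=O)[C@@H](NC(=O)NC(C)(C)C)C(C)(C)C)C(=O)NS(=O)(=O)C1CC1`: 497 ng.h/mL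
Compound 2 `C=C[C@@H]1C[C@]1(NC(=O)[C@@H]1C[C@@H](Oc2nccc3cc(OC)ccc23)CN1C(=O)[C@@H](NC(=O)N[C@H](COC)C(C)(C)C)C(C)(C)C)C(=O)NS(=O)(=O)C1CC1`: 3280 ng.h/mL
Compound 3 `C=C[C@@H]1C[C@]1(NC(=O)[C@@H]1C[C@@H](Oc2nccc3cc(OC)ccc23)CN1C(=O)[C@@H](NC(=O)N[C@H](C(=O)OC(C)(C)C)C(C)(C)C)C(C)(C)C)C(=O)NS(=O)(=O)C1CC1`: 632 ng.h/mL

Two steps tell where compound 3 stands: a 1.3-fold higher number from compound 1 to compound 3 (0.10 log units; within the scatter), and a 5.2-fold lower number from compound 2 to compound 3 (0.72 log units; beyond the scatter). Compound 4 `C=C[C@@H]1C[C@]1(NC(=O)[C@@H]1C[C@@H](Oc2nccc3cc(OC)ccc23)CN1C(=O)[C@@H](NC(=O)N[C@H](C(=O)O)C(C)(C)C)C(C)(C)C)C(=O)NS(=O)(=O)C1CC1` differs from compound 3 by hydrogen in place of tert-butyl on an oxygen next to a carbonyl group, which is hydrogen in place of tert-butyl on an oxygen next to a carbonyl group, so that tert-butoxycarbonyl becomes carboxy.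

Going by the values given here, no measured step makes this exact change, so the evidence is indirect. The closest is the exchange of methoxymethyl for tert-butoxycarbonyl, where compound 3 shows a 5.2-fold lower number from compound 2 to compound 3 (0.72 log units; beyond the scatter). That step shows that a change in this part of the side chain can move the number beyond the scatter. A step of similar size is therefore expected here, downward, although the data do not settle the direction. The expected change is a 3.2-fold lower number from compound 3 to compound 4 (0.50 log units; beyond the scatter). The estimate for compound 4 is 200 ng.h/mL. Its expected range runs from 40 ng.h/mL to 800 ng.h/mL.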

Compound 4, area under the concentration-time curve: 91 ng.h/mL
The estimate for compound 4 lay 2.2-fold (0.34 log units) above the measured number; low and high end bracket the measured number.
By their numbers in this assay, from the lowest: compound 4; then compounds 1 and 3 (each within the scatter of the next); then compound 2.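

In this assay, going from tert-butoxycarbonyl to carboxy gives a 6.9-fold lower number from compound 3 to compound 4 (0.84 log units; beyond the scatter), so the ester group that had left the number within the scatter of the tert-butyl compound does not stand for every carbonyl-bearing group at this position. With 1-carboxy-2,2-dimethylpropyl in place of tert-butyl on the amide-type nitrogen the result is a 5.5-fold lower number from compound 1 to compound 4 (0.74 log units; beyond the scatter), and with carboxy in place of methoxymethyl it is a 36-fold lower number from compound 2 to compound 4 (1.56 log units; beyond the scatter), the largest step among these compounds. The side chain at this place can therefore move the number both ways from compound 1, upward in compound 2 and downward in compound 4.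

Nothing at hand says why the carboxy compound gives the lowest number of the four. On these data alone, whether a methyl ester, a primary amide or a hydroxymethyl group on the same carbon would stand nearer compound 2 or compound 4 remains open.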